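Sulfonamide aryl variation: 2-methylphenyl replacing 3,4-dimethylphenyl

The source may report more compounds than this note shows. Statements on the series, on what has been measured and on what is new or still open speak of the compounds shown alone.

Compound 1 `Cc1ccc(NS(=O)(=O)c2ccc(N3CCNC3=O)cc2)cc1C` gives 230 nM in a functional assay on HT-29 cells (Homo sapiens) for antiproliferative activity, read by sulforhodamine B assay, with a stated time of 48 h; a lower number here means a stronger inhibitor, a higher number a weaker inhibitor.
Compound 2 `CCCCCCCc1ccc(NS(=O)(=O)c2ccc(N3CCNC3=O)cc2)cc1` gives > 1000 nM in this assay, a limit of the assay and not a number.
Compound 3 `O=C1NCCN1c1ccc(S(=O)(=O)Nc2cccc(Oc3ccccc3)c2)cc1` gives 200 nM in this assay.

Of the two numbers shown, compound 1 holds the higher one, yet compound 3 lies within the scatter of it, so no order between the two can be drawn. The value of compound 2 is a limit only (the limit of > 1000 nM in this assay, at which 1 of the 3 values shown sits). Compound 4 `Cc1ccccc1NS(=O)(=O)c1ccc(N2CCNC2=O)cc1` differs from compound 1 in a single place: 2-methylphenyl in place of 3,4-dimethylphenyl on a sulfonamide nitrogen. Among the compounds with values here, no measured pair carries this change, so its size is open. The expected step of a 2.2-fold higher number from compound 1 to compound 4 (0.34 log units; beyond the scatter) is estimated to run toward a weaker inhibitor, possibly beyond the scatter. Compound 4 is estimated at 500 nM in this assay, from 150 nM to 2000 nM.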

Compound 4, half-maximal inhibitory concentration: 200 nM
Compound 4: the middle estimate sits 2.5-fold (0.40 log units) above what was measured; measured number inside the range.
By their numbers in this assay, from the lowest: compounds 3, 4 and 1 (each within the scatter of the next). At a limit, above all of these: compound 2.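

In this assay the change from 3,4-dimethylphenyl to 2-methylphenyl on a sulfonamide nitrogen gives a 1.2-fold lower number from compound 1 to compound 4 (0.06 log units; within the scatter) and so leaves activity without a readable shift. Within the data shown here, this is the first step that can be read at this place, and it shows that the place accepts this change of methyl pattern on the phenyl ring. Nothing measured here gives a cause for this step.

As far as these compounds go, what an amine or a carboxylic acid on this phenyl ring would do remains open. So does the effect of an unsubstituted phenyl at this nitrogen.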